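A few compounds are considered here, and "the series" means these few. Any claim that something is new, unique, unknown or untested is made for them only; others in the source may bear on it.

Measured in a functional assay on A549 cells (Homo sapiens) for antiproliferative activity, read by MTT assay, with a stated time of 72 h; a lower number here means a stronger inhibitor, a higher number a weaker inhibitor:

Compound 1 `CCCCN(CCCC)C(=S)Sc1ccccc1`: 9760 nM
Compound 2 `CC(C)(C)OC(=O)N1CCN(C(=S)Sc2ccc(C(C)(C)C)cc2)CC1`: 769 nM
Compound 3 `COc1ccc(SC(=S)N2CCN(C(=O)OC(C)(C)C)CC2)cc1`: 712 nM

In this assay, compound 3 has the lowest of the three numbers, but it lies within the scatter of compound 2, so these two cannot be told apart. Compound 1 gives a clearly higher number, beyond the scatter of both.

The next compound, compound 4 `CC(C)(C)OC(=O)N1CCN(C(=S)Sc2ccc(Cl)cc2)CC1`, carries chloro in place of methoxy on an aromatic carbon, para to a large group: chloro in place of methoxy on an aromatic carbon. Among the compounds with values here, one measured step bears on this, a swap of groups on an aromatic carbon, methoxy in place of tert-butyl: a 1.1-fold lower number from compound 2 to compound 3 (0.03 log units; within the scatter). Within the data shown here, that single small step is thin evidence, and no chloro compound has been measured yet. Even so, no change beyond the scatter is expected in this assay. The expected step is a 1.0-fold lower number from compound 3 to compound 4 (0.01 log units; within the scatter). The estimate for compound 4 is 700 nM, with an expected range from 300 nM to 1650 nM.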

Compound 4, half-maximal inhibitory concentration: 1070 nM
The estimate for compound 4 lay 1.5-fold (0.18 log units) below the measured number; measured number inside the range.
By their numbers in this assay, from the lowest: compounds 3, 2 and 4 (each within the scatter of the next); then compound 1.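

In this assay the swap to chloro on this aromatic carbon, para to a large group, gives a small step (a 1.5-fold higher number from compound 3 to compound 4 (0.18 log units; within the scatter)), and the swap from tert-butyl to chloro gives another (a 1.4-fold higher number from compound 2 to compound 4 (0.14 log units; within the scatter)). Both steps lie within the scatter, so compound 2, compound 3 and compound 4 cannot be told apart, and three quite different groups, now including a single chlorine atom, read alike at this position. No measurement available here bears on why these groups read alike.

From the compounds shown here alone, whether an amine or a carboxylic acid on this carbon would move the number beyond the scatter remains open. Also open, going by these compounds, is whether chloro, methoxy and tert-butyl would read alike on the core of compound 1.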